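A few compounds are considered here, and "the series" means these few. Any claim that something is new, unique, unknown or untested is made for them only; others in the source may bear on it.

Measured so far in a functional assay on KB cells (Homo sapiens) for inhibition, with a stated time of 72 h; a lower number here means a stronger inhibitor, a higher number a weaker inhibitor:

compound 1, `COc1ccc(S(=O)(=O)N2CCc3cccc(-c4cccnc4)c32)cc1`: 95.9 nM
compound 2, `COc1ccc(S(=O)(=O)N2CCc3cccc(-c4ccc(N(C)C)cc4)c32)cc1`: 539 nM
compound 3, `COc1ccc(S(=O)(=O)N2CCc3cccc(-c4ccc(N)cc4)c32)cc1`: 249 nM

Compound 1 stands lowest of the three numbers in this assay. The nearest to it is compound 3, with a 2.6-fold higher number from compound 1 to compound 3 (0.41 log units; beyond the scatter); the furthest is compound 2, with a 5.6-fold higher number from compound 1 to compound 2 (0.75 log units; beyond the scatter). Between the two phenyl-bearing compounds, a 2.2-fold lower number from compound 2 to compound 3 (0.34 log units; beyond the scatter), so the unsubstituted amine sits between the other two.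

The next compound, compound 4 `COc1ccc(S(=O)(=O)N2CCc3cccc(-c4cccc(F)c4)c32)cc1`, differs from compound 1 in one place: 3-fluorophenyl in place of pyridin-3-yl on an aromatic carbon. Both measured steps that bear on this one also replaced pyridin-3-yl by a substituted phenyl, and both gave a higher number, modest in size. Neither, however, carried a fluorine; the entering 3-fluorophenyl brings no hydrogen-bond acceptor in place of the one that leaves, and nothing measured here tells what that costs on its own. The reasonable expectation is therefore a modest rise in the number, of the same order as the smaller of the two known steps, and compound 4 is estimated at a 2.0-fold higher number from compound 1 to compound 4 (0.30 log units; within the scatter). Compound 4 is thus expected to show about 190 nM in this assay, within a range of 70 nM to 500 nM.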

Compound 4, half-maximal inhibitory concentration: 98.5 nM
Compound 4: the middle estimate sits 1.9-fold (0.29 log units) above what was measured; the measured number falls inside the stated range.
By their numbers in this assay, from the lowest: compounds 1 and 4 (each within the scatter of the next); then compound 3; then compound 2.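

At this place on the shared core, ortho to a fused ring, this assay does not separate the two groups: a 1.0-fold higher number from compound 1 to compound 4 (0.01 log units; within the scatter). The 3-fluorophenyl group counts 0 hydrogen-bond acceptors against 1 for pyridin-3-yl, so, for this pair, the ring nitrogen is not needed to hold the number, and a ring of carbon only can serve here. The higher numbers of compound 2 and compound 3 therefore do not come with every phenyl ring at this place, as a 5.5-fold lower number from compound 2 to compound 4 (0.74 log units; beyond the scatter) and a 2.5-fold lower number from compound 3 to compound 4 (0.40 log units; beyond the scatter) show; they go with the 4-(dimethylamino)phenyl and 4-aminophenyl groups, though no available evidence explains the difference.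

The compounds shown leave open what the fluorine itself contributes, and a plain phenyl group at this place would isolate it from the effect of removing the ring nitrogen. They also leave open whether the higher numbers follow the amine itself or the place it occupies on the ring, a question that a methoxy group or a carboxylic acid on the phenyl ring could help to address.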